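A Fluoro Group on Compound 3

This account rests on a few compounds, and the source may have more. Where it says the series, first, only, none or still open, it means among the compounds named here.

In a physicochemical assay for lipophilicity, read by HPLC (on this read-out higher numbers stand for higher lipophilicity and lower numbers for lower lipophilicity), compound 1 (`Cc1ccsc1C(=CCCN(C)C(CCO)C(=O)NCc1ccccc1)c1sccc1C`) gives 5.71, compound 2 (`Cc1ccsc1C(=CCCN(C)C(CCO)C(=O)NCc1ccc(F)cc1)c1sccc1C`) gives 5.87, and compound 3 (`Cc1ccsc1C(=CCCN(C)C(CO)C(=O)NCc1ccccc1)c1sccc1C`) gives 6.26, the highest of the three numbers. Compound 4 (`Cc1ccsc1C(=CCCN(C)C(CO)C(=O)NCc1ccc(F)cc1)c1sccc1C`) differs from compound 3 in one place, with fluoro in place of hydrogen on an aromatic carbon. The same exchange has been measured once, as a number 0.16 log units higher from compound 1 to compound 2 (within the scatter). The other measured step, a number 0.55 log units higher from compound 1 to compound 3 (beyond the scatter), concerns the chain and offers no direct guide. No change beyond the scatter is therefore expected in this assay. The expected step is a number 0.16 log units higher from compound 3 to compound 4 (within the scatter). For compound 4 the estimated value is 6.42, with an expected range from 6.15 to 6.7.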

Compound 4, partition coefficient: 6.45
Estimate against measurement, compound 4: 0.03 log units below; low and high end bracket the measured number.
By their numbers in this assay, from the lowest: compounds 1 and 2 (each within the scatter of the next); then compounds 3 and 4 (each within the scatter of the next).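

With a second pair now measured in this assay, the exchange of hydrogen for fluoro on this aromatic carbon gives a number 0.19 log units higher from compound 3 to compound 4 (within the scatter) and so stays within the scatter on both chains. The chain change also carries over to the fluoro-bearing compounds, with a number 0.58 log units higher from compound 2 to compound 4 (beyond the scatter) and thus again a step beyond the scatter. Nothing available gives a measured reason for either step. Still open, on these data alone, is whether a larger group on this aromatic carbon, such as chloro or methoxy, would leave the number as little changed. Also open, as far as these compounds go, is how an amine in place of the hydroxy, or a longer chain, would read.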